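Trimming One Methyl From a Carbamate Tail

The source may report more compounds than this note shows. Statements on the series, on what has been measured and on what is new or still open speak of the compounds shown alone.

Compound 2 `CC(C)(C)OC(=O)NCCS(=O)(=O)NC(=O)c1ccc(Nc2nc(NC3(c4ccc(Cl)cc4)CC3)nc(OCC(F)(F)F)n2)cc1` gives 92% in an ADME assay on microsomes from liver (Homo sapiens) for metabolic stability, with a stated time of 10 min (on this read-out higher numbers stand for a more stable compound and lower numbers for a less stable compound), the second highest of three numbers. Its nearest neighbour, compound 3 `CCS(=O)(=O)NC(=O)c1ccc(Nc2nc(NC3(c4ccc(Cl)cc4)CC3)nc(OCC(F)(F)F)n2)cc1`, gives 100%, and the furthest, compound 1 `CCCCCNc1nc(Nc2ccc([N+](=O)[O-])cc2)nc(OCC(F)(F)F)n1`, gives 74%. The measured step that bears here is a number 8 percentage points higher from compound 2 to compound 3 (within the scatter), which took away the whole (tert-butoxycarbonyl)amino group and still stayed within the scatter. Compound 4 `CC(C)OC(=O)NCCS(=O)(=O)NC(=O)c1ccc(Nc2nc(NC3(c4ccc(Cl)cc4)CC3)nc(OCC(F)(F)F)n2)cc1` makes a far smaller cut than that: hydrogen in place of methyl on a saturated chain carbon bound to an oxygen next to a carbonyl group and two saturated chain carbons. Because removing the entire group gave only a number 8 percentage points higher from compound 2 to compound 3 (within the scatter), removing one methyl from it is expected to give no step beyond the scatter in this assay, so compound 4 is expected to show a number 1 percentage points lower from compound 2 to compound 4 (within the scatter). The estimate for compound 4 is 91%, in a range from 78% to 100%.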

Compound 4, percent of the compound remaining: 100%
The estimate for compound 4 lay 9 percentage points below the measured number; the range from low to high includes it.
By their numbers in this assay, from the lowest: compound 1; then compounds 2, 3 and 4 (each within the scatter of the next).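

In this assay, hydrogen in place of methyl on this carbamate tail gives a number 8 percentage points higher from compound 2 to compound 4 (within the scatter) and so does not separate tert-butoxycarbonyl from isopropoxycarbonyl. Putting (isopropoxycarbonyl)amino in place of hydrogen on the saturated chain carbon, two bonds along the chain from a sulfonyl sulfur, gives no change at the digits printed from compound 3 to compound 4 (within the scatter) and shows that the isopropyl carbamate, like the tert-butyl one, leaves no step beyond the scatter. Nothing available explains this result. Still open, going by these compounds, is whether a free amine, a carboxylic acid or a longer chain at this place would also stay within the scatter.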